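Notes on the substituent at the aromatic nitrogen

The source may hold more compounds than are shown below. What is called first, only, known or untested is meant among the compounds shown, and "the series" means these compounds.

In a functional assay on FaDu cells (Homo sapiens) for cytotoxicity, read by MTT assay, with a stated time of 72 h (a higher number here means that more compound is tolerated, a lower number that less compound is tolerated), compound 1 (`CCC(C)n1cc(C(=O)C(=O)Nc2ccc(OC)nc2)c2ccccc21`) gives 68 nM and compound 2 (`COCC(C)n1cc(C(=O)C(=O)Nc2ccc(OC)nc2)c2ccccc21`) gives 12 nM. Among the measured compounds shown here, compound 2 therefore holds the lower of the only two numbers available. For the measured compounds named here, the single measured step is a 5.7-fold lower number from compound 1 to compound 2 (0.75 log units; beyond the scatter), with methoxy in place of methyl on a saturated chain carbon, two bonds along the chain from an aromatic nitrogen.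

Compound 3 (`COc1ccc(NC(=O)C(=O)c2cn(CC(C)C)c3ccccc23)cn1`) keeps the shared core and changes only the group on that nitrogen: isobutyl in place of 1-(methoxymethyl)ethyl on an aromatic nitrogen. Like compound 1, compound 3 has no methoxy group, although its isobutyl group is not the group carried by compound 1, and no measured step covers that difference. Going by the values given here, the step of a 5.7-fold lower number from compound 1 to compound 2 (0.75 log units; beyond the scatter) is thus the only guide, read in reverse. A step of similar size towards a higher number is expected, beyond the scatter. The estimated step is a 4.6-fold higher number from compound 2 to compound 3 (0.66 log units; beyond the scatter). For compound 3 the estimated value is 55 nM, with an expected range of 18 nM to 160 nM.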

Compound 3, concentration lethal to 50% of the cells: 317 nM
Estimate against measurement, compound 3: 5.8-fold (0.76 log units) below, outside the stated range (above it).
By their numbers in this assay, from the lowest: compound 2; then compound 1; then compound 3.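

In this assay the position responds to the shape of an all-carbon group alone, with no oxygen entering or leaving: isobutyl in place of sec-butyl on the aromatic nitrogen gives a 4.7-fold higher number from compound 1 to compound 3 (0.67 log units; beyond the scatter). Among the compounds shown here, the methoxy step therefore no longer stands as the only measured change that moves the number at this position, and the arrangement of the carbon chain has to be counted as a variable in its own right. The widest step in the set is a 26-fold higher number from compound 2 to compound 3 (1.42 log units; beyond the scatter), which places the 1-(methoxymethyl)ethyl and isobutyl groups at the two ends of the measured order, with sec-butyl in the middle, although nothing available accounts for these differences.

From the compounds shown here alone, whether the methoxy group lowers the number to the same degree on other chains remains open, since a 2-methoxyethyl or 2-methoxy-2-methylpropyl group would separate its contribution from that of the branching. It is equally unsettled whether the oxygen itself is required, which a hydroxyl group or a dimethylamino group at the same chain carbon would test.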